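Aryl Amide to Piperidine Amide: What Clearance to Expect

This account rests on a few compounds, and the source may have more. Where it says the series, first, only, none or still open, it means among the compounds named here.

Of the compounds shown here, two have so far been measured in an in vitro ADME assay on microsomes from liver (Homo sapiens) for pharmacokinetics, read by LC-MS, with a stated time of 10 min, tested at 1 uM; on this read-out higher numbers stand for fast clearance and lower numbers for slow clearance. Compound 1 `CC(C)c1ccc(NC(=O)[C@H]2CN(C)C[C@@H]2c2ccc(/C=C/C(=O)Nc3ccccc3N)cc2)cc1` gives 10 mL/min/kg, and compound 2 `CN1C[C@H](C(=O)Nc2ccc(F)c(Br)c2)[C@@H](c2ccc(/C=C/C(=O)Nc3ccccc3N)cc2)C1` gives 15 mL/min/kg. Among the measured compounds shown here, the single measured step, a 1.5-fold higher number from compound 1 to compound 2 (0.18 log units; within the scatter), places compound 2 alongside compound 1 with the two numbers inside the scatter of each other; compound 2 is the one from which the next change departs.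

Compound 3 `CN1C[C@H](C(=O)N2CCCCC2)[C@@H](c2ccc(/C=C/C(=O)Nc3ccccc3N)cc2)C1` differs from compound 2 by piperidin-1-yl in place of (3-bromo-4-fluorophenyl)amino on a carbonyl carbon. For the measured compounds named here, the one step on record exchanged one aryl group for another on an amide-type nitrogen and stayed within the scatter, so it bears only loosely on a change that removes an aryl amino group altogether and brings in a saturated ring. Going by the values given here, no measured pair shows a change of this kind, and there is no basis here for predicting a shift in either direction. The expectation is therefore a step no larger than the scatter, no change at the digits printed from compound 2 to compound 3 (within the scatter). For compound 3 the estimate in this assay is 15 mL/min/kg, with a range from 7 mL/min/kg to 32 mL/min/kg.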

Compound 3, clearance: 9 mL/min/kg
The estimate for compound 3 lay 1.7-fold (0.22 log units) above the measured number; the range from low to high includes it.
By their numbers in this assay, from the lowest: compounds 3, 1 and 2 (each within the scatter of the next).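

With compound 3, the place on the carbonyl carbon carries something other than an aryl amino group: piperidin-1-yl, a non-aromatic ring with no hydrogen-bond donor, stands where (3-bromo-4-fluorophenyl)amino stood, and this assay shows a 1.7-fold lower number from compound 2 to compound 3 (0.22 log units; within the scatter) for this exchange. Set against the other aryl amide, the same kind of exchange gives a 1.1-fold lower number from compound 1 to compound 3 (0.05 log units; within the scatter) on this read-out. Among these three compounds, then, neither the aromatic ring nor the amide hydrogen of the group on this carbonyl carbon is needed for the clearance numbers to stay within the scatter of one another, and nothing at hand explains this closeness.

As far as these compounds go, what a morpholine, an open-chain amine such as diethylamino, or a smaller ring such as pyrrolidine would give on the same carbonyl carbon remains open. All three compounds also share the rest of the structure, so they leave open whether a change elsewhere, for example on the ring nitrogen that carries the methyl group, would move the number beyond the scatter.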